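The source may hold more compounds than are shown below. What is called first, only, known or untested is meant among the compounds shown, and "the series" means these compounds.

The measured compounds are:

compound 1, `Cc1ccc(OC(=O)/C=C/c2ccc(Cl)cc2Cl)c(C(C)C)c1`, which in a functional assay on the whole organism for inhibition, with Brassica rapa subsp. chinensis as the target, with a stated time of 3 days, tested at 100 ppm (a lower number here means less inhibition of growth, a higher number more inhibition of growth at the concentration tested), gives 32%;
compound 2, `O=C(/C=C/c1ccc(Cl)cc1Cl)OCCOc1ccccc1`, which in this assay gives 33%;
compound 3, `Cc1ccc(OC(=O)/C=C/c2ccc(Cl)cc2)c(C(C)C)c1`, which in this assay gives 41%.

Compounds 1 and 3 share one core and differ in a single place: hydrogen in place of chloro on an aromatic carbon. This change gave a number 9 percentage points higher from compound 1 to compound 3 (within the scatter), so the two numbers lie within the usual scatter of each other and no change in growth inhibition can be read from them.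

Compound 2 has a different core; how the core of compound 2 differs from the core of compound 1 is not broken down here. Its value and that of compound 1 are within the scatter of each other, and so are its value and that of compound 3.

Compound 4, `O=C(/C=C/c1ccc(Cl)cc1)OCCOc1ccccc1`, has not yet been measured. It comes from compound 2 by the same change that leads from compound 1 to compound 3: hydrogen in place of chloro on an aromatic carbon. The surroundings of the place are described in the same words for both pairs, so the change is the same.

Because the earlier change gave a number 9 percentage points higher from compound 1 to compound 3 (within the scatter), a step of similar size is expected from compound 2 to compound 4 in this assay, namely a number 9 percentage points higher from compound 2 to compound 4 (within the scatter). On this basis compound 4 is estimated to give about 42%, with the likely range running from 28% to 56%.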

Compound 4, percent growth inhibition at one concentration: 30%
The estimate for compound 4 lay 12 percentage points above the measured number; measured number inside the range.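

Replacing the chloro group with hydrogen on the core of compound 2 gives, in this assay, a number 3 percentage points lower from compound 2 to compound 4 (within the scatter), so no change in growth inhibition can be read from this pair. Set beside the earlier step, the new one does not differ from it by more than repeated measurements can account for: the same change on two cores in this assay, a number 9 percentage points higher (within the scatter) from compound 1 to compound 3 and a number 3 percentage points lower (within the scatter) from compound 2 to compound 4, 12 percentage points apart, within the scatter of two such steps. This gives no sign that the core alters what the change does, but it does not prove that the change carries over from one core to the other in the same way; neither step stands clear of the scatter, and a small real effect on either core could stay hidden in these numbers.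

On these data alone, it remains open whether a different group at this place on the ring, such as a methoxy group, a nitrile or an amine, would move growth inhibition clear of the scatter. Also open, as far as these compounds go, is how the same exchange of chloro for hydrogen would behave on a core with an amide in place of the ester, or with a longer chain in the part attached to the ester oxygen.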